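Notes on removing the ring fluorine from compound 1

This account rests on a few compounds, and the source may have more. Where it says the series, first, only, none or still open, it means among the compounds named here.

Measured compounds:
compound 1 `Cc1cc(C)cc(C(=O)N(CC(=O)NCc2ccccc2)Cc2ccc(C(=O)Nc3cc(F)ccc3N)cc2)c1` — 5720 nM
compound 2 `Cc1ccc(CNC(=O)CN(CCCCCC(=O)Nc2ccccc2N)C(=O)c2cc(C)cc(C)c2)cc1` — 18200 nM
compound 3 `Cc1cc(C)cc(C(=O)N(CCCCCC(=O)Nc2ccccc2N)CC(=O)NC2CCCCC2)c1` — 17500 nM

In a functional assay on CAL-27 cells (Homo sapiens) for cytotoxicity, read by MTT assay, with a stated time of 72 h (a lower number here means a stronger inhibitor, a higher number a weaker inhibitor), compound 1 gives the lowest of the three numbers; compound 3 and compound 2 both sit higher, and both gaps to compound 1 lie beyond the scatter. Within the data shown here, the only single-point step among the measured compounds is a 1.0-fold lower number from compound 2 to compound 3 (0.02 log units; within the scatter), which concerns the amide-type nitrogen substituent on a different part of the molecule and not the aminophenyl ring.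

Compound 4 `Cc1cc(C)cc(C(=O)N(CC(=O)NCc2ccccc2)Cc2ccc(C(=O)Nc3ccccc3N)cc2)c1` differs from compound 1 by hydrogen in place of fluoro on an aromatic carbon. Among the measured compounds shown here, no measured pair isolates this change, so the expectation rests on compound 1 alone. With nothing in the data pointing either way, the estimated step of a 1.1-fold higher number from compound 1 to compound 4 (0.06 log units; within the scatter) is expected to stay within the scatter. Compound 4 is therefore estimated at 6500 nM in this assay, with a range from 2500 nM to 17000 nM.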

Compound 4, half-maximal inhibitory concentration: 1600 nM
For compound 4 the middle estimate is 4.1-fold (0.61 log units) above the measured one; measured number outside the range, below it.
By their numbers in this assay, from the lowest: compound 4; then compound 1; then compounds 3 and 2 (each within the scatter of the next).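

In this assay, among these compounds, going from the 2-amino-5-fluorophenyl group to the 2-aminophenyl group gives a 3.6-fold lower number from compound 1 to compound 4 (0.55 log units; beyond the scatter), the first measured step at this position. The earlier compounds held no pair that changed this ring, so this position had no measured response until now; it is now shown to respond beyond the scatter to the swap of fluoro for hydrogen, with everything else in the core of compound 1 kept the same. Within this pair, the lower number belongs to the form without fluoro.

From the compounds shown here alone, whether chloro or methoxy on the same aromatic carbon would read closer to compound 1 or to compound 4 remains open, as does whether the same swap would give a similar step on the scaffolds of compound 2 and compound 3. Nothing shown gives a measured reason for the size or direction of this step.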